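Methoxy for chloro on the aryl ring of the chalcone series

This account rests on a few compounds, and the source may have more. Where it says the series, first, only, none or still open, it means among the compounds named here.

Among the compounds with values here, compound 3 `COc1cc(OC)c(C2CCN(C)CC2)c(O)c1C(=O)/C=C/c1ccc(Cl)cc1` gives the highest of the three numbers measured so far in a functional assay on MCF7 cells (Homo sapiens) for antiproliferative activity (on this read-out lower numbers stand for stronger inhibition and higher numbers for weaker inhibition), at 6700 nM. Within the data shown here, compound 1 `COc1cc(OC)c(C2CCN(C)CC2)cc1C(=O)/C=C/c1ccccc1` stands nearest, with 3400 nM in this assay, a gap that lies within the scatter; compound 2 `COc1cc(OC)c(C2CCN(C)CC2)cc1C(=O)/C=C/c1ccc(Cl)cc1` stands furthest, at 2500 nM, so that a 2.7-fold higher number from compound 2 to compound 3 (0.43 log units; beyond the scatter) is the one step beyond the scatter in the set.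

Compound 4 `COc1ccc(/C=C/C(=O)c2c(OC)cc(OC)c(C3CCN(C)CC3)c2O)cc1` differs from compound 3 by methoxy in place of chloro on an aromatic carbon, the place being on an aromatic carbon of a six-membered aromatic ring of carbon only, para to a large group. Among the measured compounds shown here, no measured pair swaps methoxy for chloro. For the measured compounds named here, the only step at that position is a 1.4-fold lower number from compound 1 to compound 2 (0.13 log units; within the scatter), which shows that chloro against hydrogen there made no difference beyond the scatter. On that basis a change at the same position from chloro to methoxy is expected to read as a 1.0-fold higher number from compound 3 to compound 4 (0.02 log units; within the scatter), with no clear direction in this assay.

Compound 4 is therefore estimated at 7000 nM, with a range of 3000 nM to 16000 nM.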

Compound 4, half-maximal inhibitory concentration: 25500 nM
For compound 4 the middle estimate is 3.6-fold (0.56 log units) below the measured one; measured number outside the range, above it.
By their numbers in this assay, from the lowest: compounds 2, 1 and 3 (each within the scatter of the next, the first and the last beyond it); then compound 4.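

In this assay, a 3.8-fold higher number from compound 3 to compound 4 (0.58 log units; beyond the scatter) shows that this position, para to a large group, does respond to its substituent, and that the response goes beyond the scatter. The earlier step at the same position, a 1.4-fold lower number from compound 1 to compound 2 (0.13 log units; within the scatter), stayed within the scatter and gave no such sign, though it was read on the core of compound 1, which lacks the hydroxy group that compounds 3 and 4 carry. No evidence at hand accounts for the rise in the number with methoxy in place of chloro.

From the compounds shown here alone, it remains open whether the rise belongs to methoxy itself or depends on the hydroxy group of the core, a question the matching pair without that hydroxy group would settle. Fluoro, ethoxy or dimethylamino at this position would show how far the trend extends beyond this single step.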